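The source may report more compounds than this note shows. Statements on the series, on what has been measured and on what is new or still open speak of the compounds shown alone.

Working notes on the series.

For the measured compounds named here, compound 3 `C/N=C(\S)NCCCCCCn1nc(-c2ccccc2)ccc1=O` stands lowest of the three numbers measured so far: in a functional assay on the whole organism with Rattus norvegicus as the target, at a dose of 100 mg/kg (on this read-out higher numbers stand for more inhibition at the one dose given (going by the name of the read-out) and lower numbers for less inhibition), compound 3 gives 22.2%. Its nearest neighbour is compound 2 `C/N=C(/NC#N)N(C)CCCCn1nc(-c2ccccc2)ccc1=O`, for which this assay gives 27%, a gap within the scatter, so no order between the two is claimed. Furthest off is compound 1 `C/N=C(\S)NCCCCCn1nc(-c2ccccc2)ccc1=O`, which in this assay gives 68.9%.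

Compound 4 `CC/N=C(\S)NCCCCn1nc(-c2ccccc2)ccc1=O` is not yet measured. Relative to compound 3 the change is a group of 6 heavy atoms (3 carbon, 2 nitrogen, 1 sulfur; no ring) in place of a group of 7 heavy atoms (4 carbon, 2 nitrogen, 1 sulfur; no ring), on a saturated chain carbon, four bonds along the chain from an aromatic nitrogen.

Going by the values given here, the steps that bear on it are a number 46.7 percentage points lower from compound 1 to compound 3 (beyond the scatter), where one more chain carbon entered and the number fell sharply, and a number 4.8 percentage points lower from compound 2 to compound 3 (within the scatter), which stayed within the scatter. The step from compound 3 to compound 4 takes a chain carbon away again, so the sense of the first step argues for an upward move; the second step, and compound 2 sitting at a four-carbon chain with a modest number, argue for restraint.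

A moderate rise is therefore expected for compound 4, a number 15.8 percentage points higher from compound 3 to compound 4 (beyond the scatter), with compound 4 estimated at 38%, in the range 12% to 68%.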

Compound 4, a percentage reported as inhibition, in the whole organism at one dose (the size of the read-out at that dose, not a potency): 67.7%
Compound 4: middle estimate off by 29.7 percentage points, on the low side; the range from low to high includes it.
By their numbers in this assay, from the lowest: compounds 3 and 2 (each within the scatter of the next); then compounds 4 and 1 (each within the scatter of the next).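

In this assay, the group of 6 heavy atoms on a saturated chain carbon, four bonds along the chain from an aromatic nitrogen, gives a large upward move against both other groups at that place: a number 45.5 percentage points higher from compound 3 to compound 4 (beyond the scatter), and a number 40.7 percentage points higher from compound 2 to compound 4 (beyond the scatter). Compound 1 carries a group of the same atom count and composition, and a number 1.2 percentage points lower from compound 1 to compound 4 (within the scatter), so the two forms of this group are not told apart by this read-out. No measurement at hand bears on why the number moves so sharply at this place.

On these data alone, whether an amine or a carboxylic acid in place of this group would keep a number of this size stays open. As far as these compounds go, how far these steps hold at other doses also stays open, since each number comes from a single dose.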